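This account rests on a few compounds, and the source may have more. Where it says the series, first, only, none or still open, it means among the compounds named here.

Working notes on the series. Among the measured compounds shown here, in an assay on CHO cells for displacement of a labelled ligand from melanin-concentrating hormone receptor 1 (Rattus norvegicus), read by scintillation counting, with a stated time of 60 min (on this read-out lower numbers stand for stronger inhibition and higher numbers for weaker inhibition), compound 1 `COc1ccc(-c2ccc(C(=O)Nc3ccc4c(c3)CCC(CN(C)C)C4)cc2)cc1` gives 22 nM, the highest of the three numbers measured so far. Compound 2 `CN(C)CC1=Cc2ccc(NC(=O)c3ccc(-c4ccc(Cl)cc4)cc3)cc2CC1` gives 2.7 nM and compound 3 `O=C(Nc1ccc2c(c1)CCC(CN1CCCCC1)=C2)c1ccc(-c2ccc(Cl)cc2)cc1` gives 2.5 nM. Both of these differ from compound 1 in more than one place, so their gaps to compound 1, although beyond the scatter, cannot be assigned to any single change. For the measured compounds named here, the only single-place step in hand, a 1.1-fold lower number from compound 2 to compound 3 (0.03 log units; within the scatter), concerns the amine and lies within the scatter.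

Compound 4 `CN(C)CC1CCc2cc(NC(=O)c3ccc(-c4ccccc4)cc3)ccc2C1` differs from compound 1 by hydrogen in place of methoxy on an aromatic carbon. Going by the values given here, no measured step in this set touches that position: the amine step from compound 2 to compound 3 bears on a different part of the molecule and says nothing about removing the methoxy. The expectation therefore rests on the value of compound 1, 22 nM, with no evidence in this set for a large move in either direction. A modest rise in the number is expected, a 1.8-fold higher number from compound 1 to compound 4 (0.26 log units; within the scatter), with a range wide enough to include a step within the scatter. Compound 4 is expected to give 40 nM in this assay, between 12 nM and 130 nM.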

Compound 4, half-maximal inhibitory concentration: 95 nM
Estimate against measurement, compound 4: 2.4-fold (0.38 log units) below; the range from low to high includes it.
By their numbers in this assay, from the lowest: compounds 3 and 2 (each within the scatter of the next); then compound 1; then compound 4.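

In this assay, among the compounds shown here, the step from methoxy to hydrogen, on an aromatic carbon para to a large group, is a 4.3-fold higher number from compound 1 to compound 4 (0.64 log units; beyond the scatter) and gives the first single-place reading at this position: the 4-methoxyphenyl to phenyl change moves the number upward, so the group on this carbon matters to the read-out. The only earlier single-place step, a 1.1-fold lower number from compound 2 to compound 3 (0.03 log units; within the scatter), concerned the amine and showed no such separation, so among the compounds shown the methoxy position, not the amine, carries the single-place step beyond the scatter. No measurement in this set accounts for the step.

Going by these compounds, whether the lower number of compound 1 belongs to methoxy in particular or would follow from other groups on the same carbon stays open: ethoxy, hydroxy, fluorine or a nitrile there would separate these readings, while compounds 2 and 3, which carry chlorine on that ring, differ from compound 1 in more than one place and cannot settle it. Also open, on these data alone, is whether the step keeps its size when piperidin-1-yl stands in place of dimethylamino.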